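The source may hold more compounds than are shown below. What is called first, only, known or untested is meant among the compounds shown, and "the series" means these compounds.

Compound 1 `O=C(O)CC/C=C\CC1COC(c2cccnc2)OC1c1cccnc1`, compound 2 `COc1ccc(OC(C)(C)C2OCC(C/C=C\CCC(=O)O)C(c3cccnc3)O2)cc1` and compound 3 `CSc1ccccc1OC(C)(C)C1OCC(C/C=C\CCC(=O)O)C(c2cccnc2)O1` share one core and differ only in the group carried on the acetal carbon. In an assay for inhibition of Thromboxane-A synthase (Homo sapiens), using microsomes (a higher number here means a weaker inhibitor, a lower number a stronger inhibitor), compound 1 gives 220 nM, compound 2 gives 41 nM, and compound 3 gives 36 nM. Compound 3 thus has the lowest of the three numbers, but its nearest neighbour, compound 2, is within the scatter, while compound 1 is beyond it. Within the data shown here, the single measured step, a 1.1-fold lower number from compound 2 to compound 3 (0.06 log units; within the scatter), shows that exchanging one aryl group for another on that oxygen left the number essentially unchanged.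

Compound 4 `CC(C)(Cc1ccccc1)C1OCC(C/C=C\CCC(=O)O)C(c2cccnc2)O1` goes further: benzyl in place of 2-(methylsulfanyl)phenoxy on a saturated chain carbon bound to two saturated chain carbons and a saturated ring carbon. Among the measured compounds shown here, no measured step covers the loss of the oxygen itself, so the step from compound 2 to compound 3 bears only loosely, and compound 1 shows merely that a quite different group there gives a higher number. A small step is therefore expected, a 1.7-fold higher number from compound 3 to compound 4 (0.22 log units; within the scatter), and compound 4 is estimated at 60 nM, in the range 20 nM to 180 nM.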

Compound 4, half-maximal inhibitory concentration: 12 nM
Compound 4: middle estimate off by 5.0-fold (0.70 log units), on the high side; the measured number lies below the stated range.
By their numbers in this assay, from the lowest: compound 4; then compounds 3 and 2 (each within the scatter of the next); then compound 1.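

In this assay, exchanging one of the two phenoxy groups for the other gave only a 1.1-fold lower number from compound 2 to compound 3 (0.06 log units; within the scatter), but this position does respond when benzyl enters. Benzyl in place of 2-(methylsulfanyl)phenoxy gives a 3.0-fold lower number from compound 3 to compound 4 (0.48 log units; beyond the scatter), and benzyl in place of 4-methoxyphenoxy gives a 3.4-fold lower number from compound 2 to compound 4 (0.53 log units; beyond the scatter). The largest step at this part of the core is 1-benzyl-1-methylethyl in place of pyridin-3-yl on a saturated ring carbon, with an 18-fold lower number from compound 1 to compound 4 (1.26 log units; beyond the scatter).

The compounds shown do not separate the loss of the oxygen from the loss of the methoxy or methylsulfanyl group, and they leave open how a methoxy group on the benzyl ring or a longer chain such as 2-phenylethyl would read. No evidence is given on why benzyl gives the lower number.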